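Oxan-4-yl amide tried in place of cyclohexylmethyl

The compounds below may be only part of what the source reports. "The series", "measured", "known", "first", "only" and "open" are said of these compounds alone.

Measured so far:
Compound 1, `CNC(=O)c1cc(C)n(Cc2cc(Cl)ccc2OCc2ccccc2)n1`: 100 nM
Compound 2, `Cc1cc(NC(=O)C(C)C)nn1Cc1cc(Cl)ccc1OCc1ccccc1`: 25.1 nM
Compound 3, `Cc1cc(NC(=O)CC2CCCCC2)nn1Cc1cc(Cl)ccc1OCc1ccccc1`: 6.31 nM

In an assay on CHO-K1 cells for displacement of a labelled ligand from prostaglandin E2 receptor EP1 subtype (Homo sapiens) (on this read-out lower numbers stand for stronger inhibition and higher numbers for weaker inhibition), compound 3 gives the lowest of the three numbers. The step of a 4.0-fold lower number from compound 2 to compound 3 (0.60 log units; beyond the scatter) and the step of a 16-fold lower number from compound 1 to compound 3 (1.20 log units; beyond the scatter) both lie beyond the scatter, so compound 3 stands apart from the other two on this read-out. The step of a 4.0-fold lower number from compound 1 to compound 2 (0.60 log units; beyond the scatter) separates the other pair.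

Compound 4, `Cc1cc(NC(=O)C2CCOCC2)nn1Cc1cc(Cl)ccc1OCc1ccccc1`, has not been measured. It differs from compound 3 in one place: oxan-4-yl in place of cyclohexylmethyl on a carbonyl carbon. The step that bears on it most directly is a 4.0-fold lower number from compound 2 to compound 3 (0.60 log units; beyond the scatter), which shows that the group on the carbonyl carbon shifts the number by a modest amount, with the larger cyclohexylmethyl giving the lower number. Oxan-4-yl is counted as smaller than cyclohexylmethyl and carries one hydrogen-bond acceptor, so a modest rise in the number is expected. The author estimates that compound 4 will give 16 nM in this assay, with a range from 5 nM to 50 nM, which corresponds to an expected step of a 2.5-fold higher number from compound 3 to compound 4 (0.40 log units; beyond the scatter).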

Compound 4, half-maximal inhibitory concentration: 63.1 nM
Estimate against measurement, compound 4: 3.9-fold (0.60 log units) below; measured number outside the range, above it.
By their numbers in this assay, from the lowest: compound 3; then compound 2; then compounds 4 and 1 (each within the scatter of the next).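

In this assay, the group on the carbonyl carbon moves the number in both directions, with a 10-fold higher number from compound 3 to compound 4 (1.00 log units; beyond the scatter) and also a 2.5-fold higher number from compound 2 to compound 4 (0.40 log units; beyond the scatter). Compound 2 and compound 3 alone would have fitted a lower number with a larger group, but compound 4 goes against that order, as oxan-4-yl is larger than isopropyl yet gives the higher number. The ((oxan-4-yl)carbonyl)amino group also loses the clear separation from methylcarbamoyl seen for the other two amides, with a 1.6-fold lower number from compound 1 to compound 4 (0.20 log units; within the scatter).

No supporting evidence is available to explain this result. The change from compound 3 to compound 4 both brings in the ring oxygen and removes the methylene link, and the compounds shown leave open which of these matters, a question that cyclohexyl directly on the carbonyl carbon or oxan-4-ylmethyl could separate.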